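The compounds below may be only part of what the source reports. "The series", "measured", "known", "first", "only" and "open" are said of these compounds alone.

Measured compounds:
compound 1 `COc1ccc(/C=N/c2c(C#N)ncn2-c2ccc(F)cc2)cc1` gives 19400 nM in a functional assay on T47D cells (Homo sapiens) for antiproliferative activity, read by MTT assay, with a stated time of 48 h; on this read-out lower numbers stand for stronger inhibition and higher numbers for weaker inhibition
compound 2 `COc1ccc(/C=N/c2c(C#N)ncn2-c2ccc(F)cc2)cc1OC` gives 7230 nM in this assay
compound 3 `COc1ccc(/C=N/c2c(C#N)ncn2Cc2ccc(F)cc2)cc1OC` gives 8200 nM in this assay

Compound 1 and compound 2 differ by methoxy in place of hydrogen on an aromatic carbon, and this change gave a 2.7-fold lower number from compound 1 to compound 2 (0.43 log units; beyond the scatter). Compound 2 and compound 3 differ on the aromatic nitrogen, with a 1.1-fold higher number from compound 2 to compound 3 (0.05 log units; within the scatter). How the core of compound 1 relates to that of compound 3 is not broken down here.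

Compound 4 `COc1ccc(/C=N/c2c(C#N)ncn2Cc2ccc(F)cc2)c(OC)c1OC` is not yet measured. Compared with compound 3 it carries methoxy in place of hydrogen on an aromatic carbon. This is the same kind of change as that from compound 1 to compound 2, but the surroundings differ: the new group now sits ortho to a large group and meta to a methoxy group, whereas before it sat meta to a large group. Among the compounds with values here, because a 2.7-fold lower number from compound 1 to compound 2 (0.43 log units; beyond the scatter) was modest and beyond the scatter, a step of similar direction is expected in this assay, though the changed surroundings and the single precedent leave it uncertain; the expected step from compound 3 is a 1.5-fold lower number from compound 3 to compound 4 (0.17 log units; within the scatter). Compound 4 is therefore estimated at 5500 nM, within 2000 nM to 15000 nM.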

Compound 4, half-maximal inhibitory concentration: > 25000 nM
Compound 4 gave a limit, no number; the forecaster's own chance of this, stated with the estimate: 2%; middle value at least 4.5-fold (0.65 log units) from the limit.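

Methoxy in place of hydrogen on an aromatic carbon does not keep its direction from one core to another in this series: the same change on two cores in this assay, a 2.7-fold lower number (0.43 log units; beyond the scatter) from compound 1 to compound 2 and an at least 3.0-fold higher number (0.48 log units; beyond the scatter) from compound 3 to compound 4, at least 8.1-fold (0.91 log units) apart, beyond the scatter of two such steps

Compound 4 gives > 25000 nM in this assay, which is a limit of the assay and not a number.

The step, an at least 3.0-fold higher number from compound 3 to compound 4 (0.48 log units; beyond the scatter), is therefore only a bound, and with one pair per core it does not show whether the place of the new methoxy or the rest of the core sets the direction.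

Still open, on these data alone, is how the same methoxy placement behaves with 4-fluorophenyl on the aromatic nitrogen. Also open, as far as these compounds go, is whether a hydroxyl, an ethoxy or an amine at that place follows methoxy.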